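Nitro for Bromo on the Shared Core: A Cytotoxicity Estimate

The source may report more compounds than this note shows. Statements on the series, on what has been measured and on what is new or still open speak of the compounds shown alone.

Measured compounds:
Compound 1, `c1ccc(-c2nnc(-c3ccc(-n4cccc4)cc3)o2)cc1`, with 256000 nM in an ADME assay on A549 cells (Homo sapiens) for cytotoxicity, read by MTT assay, with a stated time of 72 h; a lower number here means a stronger inhibitor, a higher number a weaker inhibitor.
Compound 2, `Brc1ccccc1-c1nnc(-c2ccc(-n3cccc3)cc2)o1`, with 252000 nM in this assay.

Compound 2 stands at the lowest of the two numbers shown, and its nearest neighbour is compound 1, whose number is higher by an amount within the scatter. Among the measured compounds shown here, the one measured step, a 1.0-fold lower number from compound 1 to compound 2 (0.01 log units; within the scatter), is bromo in place of hydrogen on an aromatic carbon and is itself within the scatter.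

Compound 3, `O=[N+]([O-])c1ccccc1-c1nnc(-c2ccc(-n3cccc3)cc2)o1`, has not been measured. It differs from compound 2 by nitro in place of bromo on an aromatic carbon; the nitro sits ortho to a large group. For the measured compounds named here, no measured step exchanges bromo for nitro, so the only guidance is that the step from compound 1 to compound 2 left this assay unmoved. On that basis the step from compound 2 to compound 3 is expected to be a 1.0-fold lower number from compound 2 to compound 3 (0.00 log units; within the scatter), no change beyond the scatter. Compound 3 is therefore estimated at 250000 nM, with a range from 100000 nM to 600000 nM.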

Compound 3, half-maximal inhibitory concentration: 267000 nM
Compound 3: the middle estimate sits 1.1-fold (0.03 log units) below what was measured, and the stated range covers the measured number.
By their numbers in this assay, from the lowest: compounds 2, 1 and 3 (each within the scatter of the next).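

In this assay the position on an aromatic carbon, ortho to a large group, now takes a second and quite different substituent without any readable shift: nitro in place of bromo gives a 1.1-fold higher number from compound 2 to compound 3 (0.03 log units; within the scatter) and so does not separate the two groups. Measured against hydrogen at the same place, nitro gives a 1.0-fold higher number from compound 1 to compound 3 (0.02 log units; within the scatter) and thus joins bromo, so hydrogen, bromo and nitro all lie within the scatter of one another here, even though nitro brings more heavy atoms than bromo as well as hydrogen-bond acceptors that bromo lacks. Nothing measured beyond these cell numbers bears on why the position tolerates all three alike.

The compounds shown leave open whether an amine or a carboxylic acid at this position would move the number beyond the scatter, or whether any group would. They also leave open whether bromo or nitro would behave the same way at another place on this ring, and whether changes elsewhere on the shared core would matter more in this assay than this one does.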